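This account rests on a few compounds, and the source may have more. Where it says the series, first, only, none or still open, it means among the compounds named here.

In a functional assay on HL-60 cells (Homo sapiens) for antiproliferative activity, read by MTT assay, with a stated time of 48 h (on this read-out higher numbers stand for weaker inhibition and lower numbers for stronger inhibition), compound 1 `Cn1c(N)c(-c2nc3ccccc3[nH]2)c2nc(C#N)c(C#N)nc21` gives > 50000 nM, which is a limit and not a number. Compound 3 `N#Cc1nc2c(-c3nc4ccccc4[nH]3)c(N)n(CCCO)c2nc1C#N` gives > 50000 nM, likewise a limit. Going by the values given here, compound 2 `CCCn1c(N)c(-c2nc3ccccc3[nH]2)c2nc(C#N)c(C#N)nc21` gives 45200 nM, the only actual number of the three. The rest of the picture is the limit of > 50000 nM in this assay, at which 2 of the 3 values shown sit. Compound 4 `CCN(CC)CCCCn1c(N)c(-c2nc3ccccc3[nH]2)c2nc(C#N)c(C#N)nc21` differs from compound 2 by (diethylamino)methyl in place of hydrogen on a saturated chain carbon, three bonds along the chain from an aromatic nitrogen, which also reads as propyl to 4-(diethylamino)butyl. The measured steps on this chain are an at least 1.1-fold lower number from compound 1 to compound 2 (0.04 log units; that floor lies within the scatter) and an at least 1.1-fold higher number from compound 2 to compound 3 (0.04 log units; that floor lies within the scatter), and neither shows a change beyond the scatter. Among the compounds with values here, no measured compound carries the diethylamino group, so these steps are a weak guide. The expected step in this assay is a 2.3-fold lower number from compound 2 to compound 4 (0.35 log units; beyond the scatter), a modest move towards stronger inhibition. Compound 4 is estimated at 20000 nM, with an expected range from 4000 nM to 60000 nM.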

Compound 4, half-maximal inhibitory concentration: 460 nM
Beside the measured number, compound 4's estimate is 43-fold (1.64 log units) above it; the measured number lies below the stated range.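

In this assay, the chain on the aromatic nitrogen turns out to tolerate a change that moves inhibition far more than any readable earlier step did: propyl to 4-(diethylamino)butyl gives a 98-fold lower number from compound 2 to compound 4 (1.99 log units; beyond the scatter). The other two comparisons point the same way, with an at least 100-fold lower number from compound 3 to compound 4 (2.03 log units; beyond the scatter) and an at least 100-fold lower number from compound 1 to compound 4 (2.03 log units; beyond the scatter). Both of these are floors, as their starting values are limits: the limit of > 50000 nM in this assay, at which 2 of the 4 values shown sit.

From the compounds shown here alone, what stays open is whether the terminal diethylamino group or the chain length carries this move. A shorter 2-(diethylamino)ethyl chain, or a piperidine or carboxylic acid at the chain end, could separate the two.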